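Aryl variation on the amide-type nitrogen, compounds 1 to 3

The source may hold more compounds than are shown below. What is called first, only, known or untested is meant among the compounds shown, and "the series" means these compounds.

Measured so far:
compound 1, `O=C(Nc1cccc(CNc2nccnc2Cl)c1)Nc1cccc2ccccc12`: 32700 nM
compound 2, `O=C(Nc1ccccc1)Nc1cccc(CNc2nccnc2Cl)c1`: 16300 nM

In a functional assay on MGC-803 cells (Homo sapiens) for antiproliferative activity, read by MTT assay, with a stated time of 48 h (on this read-out lower numbers stand for stronger inhibition and higher numbers for weaker inhibition), compound 2 gives 16300 nM, the lowest of the two numbers recorded. Compound 1 gives 32700 nM in this assay, and the gap between the two falls within the usual scatter, so no order between them can be read. Both share the same core and differ only in the aryl group carried on the amide-type nitrogen.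

Compound 3, `Cc1ccc(NC(=O)Nc2cccc(CNc3nccnc3Cl)c2)c(C)c1`, has not yet been measured. It departs from compound 2 by a single change: 2,4-dimethylphenyl in place of phenyl on an amide-type nitrogen. Among the measured compounds shown here, no step between measured compounds matches this change, so its size cannot be taken from the data. For the measured compounds named here, the only comparison available, compound 1 against compound 2, shows that a larger aryl group at this position did not move the number beyond the scatter. On that basis the expected step is small or none beyond the scatter, with no clear direction: a 1.1-fold lower number from compound 2 to compound 3 (0.04 log units; within the scatter) is the estimated step. Compound 3 is estimated at 15000 nM, within a range of 5000 nM to 45000 nM.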

Compound 3, half-maximal inhibitory concentration: 10100 nM
For compound 3 the middle estimate is 1.5-fold (0.17 log units) above the measured one; measured number inside the range.
By their numbers in this assay, from the lowest: compounds 3, 2 and 1 (each within the scatter of the next, the first and the last beyond it).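

In this assay, 2,4-dimethylphenyl in place of phenyl on an amide-type nitrogen gives a 1.6-fold lower number from compound 2 to compound 3 (0.21 log units; within the scatter), so a phenyl ring carrying two methyl groups is tolerated here, but no order between these two compounds can be read. The new information lies in the wider pair: compound 3 at 10100 nM and compound 1 at 32700 nM lie beyond the scatter of each other, the first gap at this position that can be read, while compound 2 stays within the scatter of both. Among the compounds shown here, these two compounds differ only in the aryl group on the amide-type nitrogen, so this position can change the number in this assay, though the series so far shows only a modest spread. No measurement bears on the reason for this gap.

On these data alone, whether a single methyl group on the phenyl ring gives a number like that of compound 3 remains open. Also open, as far as these compounds go, is how the series reads with a methoxy group, an amine or a carboxylic acid on that ring, or with cyclohexyl in place of the aryl group.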